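Aryl swap on the dichlorinated styryl lactone series

The source may hold more compounds than are shown below. What is called first, only, known or untested is meant among the compounds shown, and "the series" means these compounds.

Measured so far:
- compound 1 `Cc1ccccc1-c1cc(Cl)cc(Cl)c1/C=C/[C@@H]1C[C@@H](O)CC(=O)O1` — 370 nM
- compound 2 `Cc1cc(-c2cccc(Cl)c2/C=C/[C@@H]2C[C@@H](O)CC(=O)O2)ccc1F` — 30 nM
- compound 3 `O=C1C[C@H](O)C[C@@H](/C=C/c2c(Cl)cc(Cl)cc2-c2cc(Cl)cc(Cl)c2)O1` — 37 nM

All three were run in an assay for inhibition of 3-hydroxy-3-methylglutaryl-coenzyme A reductase (Rattus norvegicus); on this read-out higher numbers stand for weaker inhibition and lower numbers for stronger inhibition. Compound 3 gives 37 nM, the second highest of the three numbers: compound 2, at 30 nM, sits within the scatter of it, while compound 1, at 370 nM, lies well beyond it.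

For the measured compounds named here, the one single-point step in hand is a 10-fold lower number from compound 1 to compound 3 (1.00 log units; beyond the scatter). It shows that the group on this aromatic carbon matters, and that a 3,5-dichlorophenyl there is clearly the better of the two tried.

Compound 4 `Cc1cc(-c2cc(Cl)cc(Cl)c2/C=C/[C@@H]2C[C@@H](O)CC(=O)O2)ccc1F` carries the change (4-fluoro-3-methylphenyl in place of 3,5-dichlorophenyl on an aromatic carbon). Going by the values given here, no measured step covers this exact exchange. Compound 2, however, already bears the 4-fluoro-3-methylphenyl group, on a core with one chloro group, and its number stands within the scatter of compound 3. The entering group is thus known to be compatible with low numbers on a closely related core, and nothing in hand points to a shift of the size seen from compound 1 to compound 3.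

Compound 4 is therefore expected to land near compound 3, with an estimated step of a 1.2-fold lower number from compound 3 to compound 4 (0.09 log units; within the scatter). The estimate for compound 4 is 30 nM, with a range from 10 nM to 100 nM.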

Compound 4, half-maximal inhibitory concentration: 29 nM
Beside the measured number, compound 4's estimate is 1.0-fold (0.01 log units) above it; measured number inside the range.
By their numbers in this assay, from the lowest: compounds 4, 2 and 3 (each within the scatter of the next); then compound 1.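

In this assay, a 1.3-fold lower number from compound 3 to compound 4 (0.11 log units; within the scatter) shows that 3,5-dichlorophenyl and 4-fluoro-3-methylphenyl cannot be told apart on this aromatic carbon, and a 1.0-fold lower number from compound 2 to compound 4 (0.01 log units; within the scatter), with chloro in place of hydrogen on the core, shows no separation between the two cores when 4-fluoro-3-methylphenyl is the aryl group. The second route to a low number on the dichlorinated core, a 13-fold lower number from compound 1 to compound 4 (1.11 log units; beyond the scatter), joins a 10-fold lower number from compound 1 to compound 3 (1.00 log units; beyond the scatter) as a step beyond the scatter, so compound 1, with its 2-methylphenyl group, is now set apart from two different aryl groups rather than one. No measurement in hand offers an explanation for these steps.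

The compounds shown leave open whether chloro in place of hydrogen on the core would also leave the number within the scatter with aryl groups other than 4-fluoro-3-methylphenyl. They also leave open how far this aromatic carbon tolerates other substituents, such as a phenyl ring carrying an amine or a carboxylic acid, or a longer alkyl chain in place of the aryl ring.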